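The compounds below may be only part of what the source reports. "The series", "measured", "known", "first", "only" and "open" are said of these compounds alone.

Measured in an ADME assay on HEK293 cells (Homo sapiens) for inhibition, read by MTT assay, with a stated time of 3 days; a higher number here means a weaker inhibitor, a lower number a stronger inhibitor:
- compound 1 `COc1ccc(COc2cc(/C=C\c3cc(OC)c(OC)c(OC)c3)ccc2OC)cc1`: 64000 nM
- compound 2 `COCOc1ccccc1/C=C/CCCOc1cc(/C=C\c2cc(OC)c(OC)c(OC)c2)ccc1OC`: 106000 nM
- compound 3 `COCOc1ccc(/C=C/CCCOc2cc(/C=C\c3cc(OC)c(OC)c(OC)c3)ccc2OC)cc1`: 25000 nM

Compound 1 lies within the scatter of compound 2 and gives a higher number than compound 3. Compound 4 `COc1ccc(/C=C\c2cc(OC)c(OC)c(OC)c2)cc1OCCC/C=C/c1ccc(F)cc1` differs from compound 1 as follows: 4-(4-fluorophenyl)but-3-en-1-yl in place of 4-methoxyphenyl on a saturated chain carbon bound to an oxygen on an aromatic ring. It has 4-(4-fluorophenyl)but-3-en-1-yl in place of 4-methoxyphenyl on a saturated chain carbon bound to an oxygen on an aromatic ring. For the measured compounds named here, the only measured step is a 4.2-fold lower number from compound 2 to compound 3 (0.63 log units; beyond the scatter), a modest one that favours the 4-(methoxymethoxy)phenyl group on the chain. Going by the values given here, no measured step makes this exact change, so compound 3, at 25000 nM, serves as the guide. A modest lower number is therefore expected in this assay, with the expected step being a 2.1-fold lower number from compound 1 to compound 4 (0.33 log units; beyond the scatter). Compound 4 is estimated at 30000 nM, within an expected range of 12000 nM to 70000 nM.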

Compound 4, half-maximal inhibitory concentration: 115000 nM
Compound 4: middle estimate off by 3.8-fold (0.58 log units), on the low side, and the stated range ends below it.
By their numbers in this assay, from the lowest: compound 3; then compounds 1, 2 and 4 (each within the scatter of the next).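

In this assay, 4-(4-fluorophenyl)but-3-en-1-yl in place of 4-methoxyphenyl gives a 1.8-fold higher number from compound 1 to compound 4 (0.25 log units; within the scatter), so this exchange at the position shows no readable change. Fluoro in place of methoxymethoxy on an aromatic carbon gives a 4.6-fold higher number from compound 3 to compound 4 (0.66 log units; beyond the scatter), whereas 4-fluorophenyl in place of 2-(methoxymethoxy)phenyl gives a 1.1-fold higher number from compound 2 to compound 4 (0.04 log units; within the scatter), so among the compounds with this chain the lower number goes only with the 4-(methoxymethoxy)phenyl group. No measurement shown here accounts for this. Going by these compounds, whether an amine or a carboxylic acid on that aromatic carbon would match methoxymethoxy remains open.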